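Stereochemical inversion in a benzylic urea series

The compounds below may be only part of what the source reports. "The series", "measured", "known", "first", "only" and "open" are said of these compounds alone.

Measured compounds:
compound 1, `Cc1ccccc1NC(=O)N[C@@H](C)c1ccccc1`, 99%
compound 2, `CC(=O)c1ccccc1NC(=O)N[C@@H](C)c1ccccc1`, 96%
compound 3, `C[C@@H](NC(=O)Nc1ccccc1Br)c1ccccc1`, 94%

In an ADME assay on the whole organism with Oryza sativa as the target, tested at 10 uM (on this read-out lower numbers stand for a stronger effect and higher numbers for a weaker effect at the one concentration tested), the three compounds sit close together. Compound 3 gives 94%, a value that lies within the usual scatter of both compound 2 and compound 1; no ordering among the three can be read from these numbers. Among the measured compounds shown here, the only step available, a number 3 percentage points lower from compound 1 to compound 2 (within the scatter), concerns a substituent exchange on the aromatic ring and is itself within the scatter.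

Compound 4, `C[C@H](NC(=O)Nc1ccccc1Br)c1ccccc1`, is the next compound. Its change from compound 3 is the two compounds have the same atoms and bonds and differ only in configuration as drawn: 1 of 1 stereo elements differ; a stereocentre at a saturated chain carbon is drawn R in compound 3 and S in compound 4. For the measured compounds named here, no measured step involves a change of configuration, so nothing in the data so far speaks directly to it; the one step on record, being within the scatter, gives no reason to expect a shift beyond it in this assay.

Compound 4 is therefore estimated at 94% in this assay, with a range from 84% to 100%. The expected step is no change at the digits printed from compound 3 to compound 4 (within the scatter), within the scatter.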

Compound 4, a percentage reported as activity, at one concentration (the size of the read-out at that concentration, not a potency): 102%
Compound 4: the middle estimate sits 8 percentage points below what was measured; measured number above the stated range.
By their numbers in this assay, from the lowest: compounds 3, 2, 1 and 4 (each within the scatter of the next).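

Configuration at the saturated chain carbon now has its first reading in this assay, a number 8 percentage points higher from compound 3 to compound 4 (within the scatter), and this step isolates that stereocentre alone: the fact that compounds 3 and 4 differ only in the configuration as drawn. On the aromatic carbon, bromo in place of methyl gives a number 3 percentage points higher from compound 1 to compound 4 (within the scatter), and bromo in place of acetyl gives a number 6 percentage points higher from compound 2 to compound 4 (within the scatter). Across these four compounds, neither the inversion nor the exchange of these substituents gives a step beyond the scatter, so neither the stereocentre nor the aromatic substituent can yet be said to matter in this series.

Going by these compounds, whether an amine or a carboxylic acid on the aromatic carbon, or a longer chain at the saturated chain carbon, would give a step beyond the scatter in this assay stays open. Also open, on these data alone, is whether configuration would matter on any other substituent than bromo.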